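The source may report more compounds than this note shows. Statements on the series, on what has been measured and on what is new or still open speak of the compounds shown alone.

In an ADME assay on KB cells (Homo sapiens) for cytotoxicity (a higher number here means that more compound is needed for the effect, a lower number that less compound is needed), compound 1 `CCOC(=O)N1[C@@H]2C=C[C@@](OC)(C(=O)c3c2cc(OC)c(OC)c3OCc2ccc(F)cc2)N1C(=O)OCC` gives 51.8 ug/mL and compound 2 `COC(=O)N1[C@@H]2C=C[C@@](OC)(C(=O)c3c2cc(OC)c(OC)c3OCc2ccc(F)cc2)N1C(=O)OC` gives 56.6 ug/mL. For the measured compounds named here, these two numbers lie within the usual scatter of each other, so compound 1 stands level with the only other measured compound. Compound 3 `CCOC(=O)N1[C@@H]2C=C[C@@](OC)(C(=O)c3c2cc(OC)c(OC)c3OCc2ccc(OC)cc2)N1C(=O)OCC` keeps the core of compound 1 but has methoxy in place of fluoro on an aromatic carbon, turning 4-fluorobenzyl into 4-methoxybenzyl (methoxy in place of fluoro on an aromatic carbon). Going by the values given here, no measured pair shows what this change does in this assay, so the data point to no direction, and no shift beyond the scatter is expected. This expectation starts from compound 1 at 51.8 ug/mL. The expected step is small, a 1.0-fold lower number from compound 1 to compound 3 (0.02 log units; within the scatter). For compound 3 the estimated value is 50 ug/mL, with an expected range from 25 ug/mL to 100 ug/mL.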

Compound 3, concentration for half-maximal effect: 63.1 ug/mL
Estimate against measurement, compound 3: 1.3-fold (0.10 log units) below, within the range that was stated.
By their numbers in this assay, from the lowest: compounds 1, 2 and 3 (each within the scatter of the next).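

In this assay, for the compounds shown here, the first pair for this change gives a 1.2-fold higher number from compound 1 to compound 3 (0.09 log units; within the scatter), so methoxy in place of fluoro on this aromatic carbon, para to a large group, moves the number no further than the scatter. At this position, on the core of compound 1, 4-fluorobenzyl and 4-methoxybenzyl therefore stand level in this read-out, although this rests on a single pair. Nothing available here bears on why the two compounds stand level.

As far as these compounds go, it remains open whether another group at this position, such as an amine, a carboxylic acid or a longer alkoxy chain, would move the number beyond the scatter. From the compounds shown here alone, it also remains open whether the change from fluoro to methoxy would read the same way on the core of compound 2.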